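Cytotoxicity limits across three amide analogues

A few compounds are considered here, and "the series" means these few. Any claim that something is new, unique, unknown or untested is made for them only; others in the source may bear on it.

Compound 1, `CC(C)N(Cc1cccc(OCCCCCC(=O)O)c1)C(=O)c1ccc(-c2cccc(N(C)C)c2)cc1`: in an ADME assay on BJ cells (Homo sapiens) for cytotoxicity, read by CellTiter-Glo and resazurin assay, with a stated time of 72 h (on this read-out lower numbers stand for an effect already at smaller amounts and higher numbers for an effect only at larger amounts of compound), compound 1 gives > 26000 nM, which is a limit of the assay rather than a number.
Compound 2, `CC(C)N(Cc1cccc(OCCCCCC(=O)O)c1)C(=O)c1ccc(-c2cccc(O)c2)cc1`: in this assay compound 2 gives > 26000 nM, also a limit.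
Compound 3, `CCOC(=O)CCCCCOc1cccc(CN(C(=O)c2ccc(-c3cccnc3)cc2)C(C)C)c1`: in this assay compound 3 gives > 26000 nM, again a limit.

Compound 3 therefore stands at the limit of this assay, like the other two compounds shown, as summarised by the limit of > 26000 nM in this assay, at which 3 of the 3 values shown sit. Among the compounds with values here, the one measured step, a step that the two limits leave unreadable from compound 1 to compound 2, cannot be read because both of its ends are limits, so it gives no guide to the size of any change. Compound 4, `CCOC(=O)CCCCCOc1cccc(CN(C(=O)c2ccc(-c3cccc(C(F)(F)F)c3)cc2)C(C)C)c1`, has not yet been measured. Within the data shown here, it differs from compound 3 by 3-(trifluoromethyl)phenyl in place of pyridin-3-yl on an aromatic carbon, a change at a different part of the molecule from the measured step, so no measured step bears on it directly. With every shown value at the limit, the expectation for compound 4 is that the step that the limit leaves unreadable from compound 3 to compound 4 stays within the scatter and that the assay again reports a limit. The estimate for compound 4 in this assay is 30000 nM, with a range from 12000 nM to 80000 nM.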

Compound 4, half-maximal effective concentration: < 1.3 nM
Compound 4 gave a limit, no number (the forecaster's own chance of this, stated with the estimate: 80%); middle value at least 23000-fold (4.36 log units) away from the limit.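

On an aromatic carbon of a six-membered aromatic ring of carbon only, para to a large group, 3-(trifluoromethyl)phenyl in place of pyridin-3-yl gives an at least 20000-fold lower number from compound 3 to compound 4 (4.30 log units; beyond the scatter) in this assay. Compound 4 sits at the opposite end of the assay, and its value is also a limit rather than a number: the limit of < 1.3 nM in this assay, at which 1 of the 4 values shown sits. The earlier compounds shown here gave no sign that any change could produce an effect at small amounts, whereas this single change shows that the group at this position can move the read-out across the whole range of the assay.

The change removes a ring nitrogen and adds a trifluoromethyl group together, so a plain phenyl ring would be needed to separate the two. As far as these compounds go, it also remains open whether the effect persists with a carboxylic acid in place of the ethyl ester.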